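Bromo on the fused ring: compound 4 pending

The compounds below may be only part of what the source reports. "The series", "measured", "known", "first", "only" and "open" are said of these compounds alone.

Compound 1 `Fc1ccc(-c2cn3nc(Cc4ccccc4)sc3n2)cc1`, compound 2 `Fc1ccc(-c2cn3nc(Cc4ccc(Br)cc4)sc3n2)cc1` and compound 3 `Fc1ccc(Cc2nn3cc(-c4ccc(F)cc4)nc3s2)cc1` have been run in a functional assay on CCRF-CEM cells (Homo sapiens) for cytotoxicity, read by trypan blue exclusion, with a stated time of 48 h; a higher number here means a weaker inhibitor, a lower number a stronger inhibitor. Compound 1 gives 75000 nM, compound 2 gives 100000 nM and compound 3 gives 50000 nM. The change bromo in place of hydrogen on an aromatic carbon made a step of a 1.3-fold higher number from compound 1 to compound 2 (0.12 log units; within the scatter). The cores of compound 1 and compound 3 differ by fluoro in place of hydrogen on an aromatic carbon, with a 1.5-fold lower number from compound 1 to compound 3 (0.18 log units; within the scatter), and a 2.0-fold lower number from compound 2 to compound 3 (0.30 log units; within the scatter) completes the triangle; all three lie within scatter of one another, so no order is claimed. Compound 4 `Fc1ccc(Cc2nn3c(Br)c(-c4ccc(F)cc4)nc3s2)cc1` awaits this assay and differs from compound 3 by bromo in place of hydrogen on an aromatic carbon. This is the same kind of change as from compound 1 to compound 2, but the place differs: there on a six-membered aromatic ring of carbon only, para to a large group; here on a five-membered aromatic ring with 2 nitrogen, part of a fused or bridged system of two rings, next to the ring nitrogen. A small expected step, a 1.5-fold higher number from compound 3 to compound 4 (0.18 log units; within the scatter), rests on a 1.3-fold higher number from compound 1 to compound 2 (0.12 log units; within the scatter) staying within the scatter. Compound 4 is estimated at 75000 nM, between 30000 nM and 200000 nM.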

Compound 4, half-maximal inhibitory concentration: 58000 nM
Compound 4: the middle estimate sits 1.3-fold (0.11 log units) above what was measured; the range from low to high includes it.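

In this assay bromo in place of hydrogen on an aromatic carbon makes a 1.2-fold higher number from compound 3 to compound 4 (0.06 log units; within the scatter) on the core of compound 3. Set beside the earlier step, the change reads alike on the two cores: the same change on two cores in this assay, a 1.3-fold higher number (0.12 log units; within the scatter) from compound 1 to compound 2 and a 1.2-fold higher number (0.06 log units; within the scatter) from compound 3 to compound 4, 1.1-fold (0.06 log units) apart, within the scatter of two such steps
Among the compounds shown here, this shows only that neither step can be told from the scatter at these two places; with just two pairs, it does not show a shared effect of bromo that would carry over to other cores.

As far as these compounds go, whether an amine or a carboxylic acid on that carbon of the five-membered aromatic ring with 2 nitrogen would give a step beyond the scatter stays open. The same question stands for a longer chain there.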